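A few compounds are considered here, and "the series" means these few. Any claim that something is new, unique, unknown or untested is made for them only; others in the source may bear on it.

Working notes on the series in a functional assay on the whole organism (strain Wistar) for inhibition, with Rattus norvegicus as the target, read by paw edema, with stated times of 60 min and 4 h, at a dose of 100 mg/kg by the oral route; a lower number here means less inhibition, a higher number more inhibition at the dose given (going by the name of the read-out).

Of the compounds shown here, two carry numbers so far. Compound 1 `CCNC(=O)CC1CCc2cc(OC)c(OC)cc21` gives 26.6% in this assay. Compound 2 `COc1cc2c(cc1OC)C(CC(=O)N1CCNCC1)CC2` gives 40.6% in this assay. Among the compounds with values here, the one step between them, a number 14 percentage points higher from compound 1 to compound 2 (beyond the scatter), is the only measured step in the set, and it puts compound 2 at the top of the two numbers, with compound 1 the nearest and beyond the scatter below it.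

Compound 3 `COc1cc2c(cc1OC)C(CC(=O)N1CCOCC1)CC2` is not yet measured. It differs from compound 2 in one place: morpholin-4-yl in place of piperazin-1-yl on a carbonyl carbon. Within the data shown here, no measured step bears directly on this exchange; the only step in hand, a number 14 percentage points higher from compound 1 to compound 2 (beyond the scatter), concerns a different exchange on the same carbonyl carbon and gives no reading on what the change from piperazin-1-yl to morpholin-4-yl does. With nothing to point either way, the expected step is a number 4.6 percentage points lower from compound 2 to compound 3 (within the scatter), which is within the usual scatter. Compound 3 is therefore estimated at 36% in this assay, expected to fall between 20% and 52%.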

Compound 3, a percentage reported as inhibition, in the whole organism at one dose (the size of the read-out at that dose, not a potency): 13.3%
Compound 3: middle estimate off by 22.7 percentage points, on the high side; the whole stated range lies above it.
By their numbers in this assay, from the lowest: compound 3; then compound 1; then compound 2.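

In this assay, within the data shown here, the exchange on the carbonyl carbon gives a number 27.3 percentage points lower from compound 2 to compound 3 (beyond the scatter) and shows that this position can lose as well as gain, since the earlier compounds offered only a rise. The exchange of ethylamino for morpholin-4-yl gives a number 13.3 percentage points lower from compound 1 to compound 3 (beyond the scatter) and so sets the three groups in a clear order at the dose given, from morpholin-4-yl through ethylamino to piperazin-1-yl, with every gap beyond the scatter. Piperazin-1-yl and morpholin-4-yl match in heavy atoms, ring size and hydrogen-bond acceptors, yet they are not interchangeable here, and the computed differences are a nitrogen against an oxygen and one hydrogen-bond donor against none; nothing available explains the gap.

The three compounds leave open whether the ring nitrogen with its hydrogen, the ring oxygen, or both set the gap between compound 2 and compound 3. A 4-methylpiperazin-1-yl or a piperidin-1-yl group on the same carbonyl carbon would help separate these readings, and all of this rests on a single dose, which gives the size of the effect and not a potency.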